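The source may report more compounds than this note shows. Statements on the series, on what has been measured and on what is new or still open speak of the compounds shown alone.

Measured compounds in an assay on isolated protein for activation of Nicotinamide phosphoribosyltransferase (Homo sapiens); a lower number here means that less compound is needed, a higher number that more compound is needed for the effect:

Compound 1 `CN(Cc1ccccc1)S(=O)(=O)c1ccc(NC(=O)NCc2ccncc2)cc1` gives 23 nM.
Compound 2 `O=C(NCc1ccncc1)Nc1ccc(S(=O)(=O)N2CC3CCC(C2)O3)cc1` gives 279 nM.
Compound 3 `O=C(NCc1ccncc1)Nc1ccc(S(=O)(=O)c2ccc(Cl)cc2)cc1` gives 126 nM.

Compound 3 stands second highest of these three numbers. Its nearest neighbour is compound 2, which lies above it by a 2.2-fold lower number from compound 2 to compound 3 (0.35 log units; beyond the scatter), while compound 1 lies far below it, as a 5.5-fold higher number from compound 1 to compound 3 (0.74 log units; beyond the scatter) shows. All three share the same core, a urea linked to a pyridylmethyl group, and differ only in what sits on the sulfonyl sulfur.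

Compound 4 `CCN(C1CCCC1)S(=O)(=O)c1ccc(NC(=O)NCc2ccncc2)cc1`, not yet measured, continues this series with cyclopentyl(ethyl)amino in place of 4-chlorophenyl on a sulfonyl sulfur. Within the data shown here, two measured steps bear on it. Compound 1 carries a benzyl(methyl)amino group on that sulfur, and replacing it with 4-chlorophenyl gave the modest rise recorded in a 5.5-fold higher number from compound 1 to compound 3 (0.74 log units; beyond the scatter). Compound 2 carries a bicyclic amino group there, and reached the largest number, as a 12-fold higher number from compound 1 to compound 2 (1.08 log units; beyond the scatter) shows. So an amino group on the sulfonyl sulfur can give either the lowest or the highest number in this set; the open-chain dialkylamino of compound 1 gave the lowest. Because compound 1 gives 23 nM with a related amino group, compound 4 is expected to move toward it, giving an estimated 2.5-fold lower number from compound 3 to compound 4 (0.40 log units; beyond the scatter) in this assay. The estimate for compound 4 is 50 nM, within a range of 15 nM to 200 nM.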

Compound 4, half-maximal effective concentration: 60 nM
Compound 4: middle estimate off by 1.2-fold (0.08 log units), on the low side; the range from low to high includes it.
By their numbers in this assay, from the lowest: compound 1; then compound 4; then compound 3; then compound 2.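

Among these compounds, with this assay as the read-out, putting cyclopentyl(ethyl)amino on the sulfonyl sulfur in place of 4-chlorophenyl gives a 2.1-fold lower number from compound 3 to compound 4 (0.32 log units; beyond the scatter), so a second amino group now sits below the aryl compound, while compound 2 remains the one amino compound above it. The change behind a 4.7-fold lower number from compound 2 to compound 4 (0.67 log units; beyond the scatter) links two groups of 8 heavy atoms each, so the heavy-atom count alone does not set the number here; the groups differ in the oxygen and the second ring that only compound 2 carries. Finally, a 2.6-fold higher number from compound 1 to compound 4 (0.42 log units; beyond the scatter) shows that an amino group without an aromatic ring can come fairly close to benzyl(methyl)amino, although compound 1 still gives the lowest number of the four.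

Nothing measured here explains why these groups give different numbers. From the compounds shown here alone, it remains open where a morpholine ring on the sulfonyl sulfur would fall, which would carry an oxygen in a single ring, and what a propyl chain in place of the ethyl of compound 4 would do.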